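Sulfanyl-linked series: fluoro for methoxy at the aryl ring

A few compounds are considered here, and "the series" means these few. Any claim that something is new, unique, unknown or untested is made for them only; others in the source may bear on it.

Compound 1, `CCOC(=O)[C@H](CCC(=O)O)NC(=O)c1ccc(Oc2nc3cc(N)cc(N)c3nc2-c2ccccc2)cc1`, in a functional assay on MDA-MB-231 cells (Homo sapiens) for inhibition, read by sulforhodamine B assay, with a stated time of 48 h (a higher number here means a weaker inhibitor of growth, a lower number a stronger inhibitor of growth), compound 1 gives 32400 nM.
Compound 2, `COc1ccc(CNc2nc3cc(N)cc(N)c3nc2-c2ccccc2)cc1`, in this assay compound 2 gives 13800 nM.
Compound 3, `COc1ccc(Sc2nc3cc(N)cc(N)c3nc2-c2ccccc2)cc1`, in this assay compound 3 gives < 100000 nM, which is a limit of the assay and not a number.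

Compound 3 therefore has no measured value of its own; it sits at the limit of < 100000 nM in this assay, at which 1 of the 3 values shown sits, and how far it lies from compound 1 or compound 2 cannot be read from the data. Among the measured compounds shown here, compound 2 and compound 1 carry different linkers to the shared core and are not single-point neighbours of compound 3, so no measured step bears on the change considered here.

Compound 4, `Nc1cc(N)c2nc(-c3ccccc3)c(Sc3ccc(F)cc3)nc2c1`, differs from compound 3 by fluoro in place of methoxy on an aromatic carbon of a six-membered aromatic ring of carbon only. For the measured compounds named here, no measured pair shows this exchange, so the expected step in this assay is taken as small, of no firm direction, and likely within the scatter. Compound 4 is estimated at 35000 nM, with a range from 8000 nM to 100000 nM. The expected step that the limit leaves unreadable from compound 3 to compound 4 rests on the limit of compound 3 alone and is correspondingly uncertain.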

Compound 4, concentration for total growth inhibition: 38000 nM
For compound 4 the middle estimate is 1.1-fold (0.04 log units) below the measured one; measured number inside the range.
By their numbers in this assay, from the lowest: compound 2; then compounds 1 and 4 (each within the scatter of the next).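

No step can be read from compound 3 to compound 4, since the entry for compound 3 is a limit of the assay and not a number: the limit of < 100000 nM in this assay, at which 1 of the 4 values shown sits.

In this assay the compounds shown leave open the size and direction of the change from fluoro in place of methoxy on an aromatic carbon.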